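The source may report more compounds than this note shows. Statements on the series, on what has been measured and on what is new or still open speak of the compounds shown alone.

Measured compounds:
compound 1, `COc1cccc(C(=O)Nc2cc(-c3ccccc3)nn2-c2ccccc2)c1`, 102 nM
compound 2, `O=C(Nc1cc(-c2ccccc2)nn1-c1ccccc1)c1ccncc1`, 2500 nM
compound 3, `O=C(Nc1cc(-c2ccccc2)nn1-c1ccccc1)C1CCCC1`, 3410 nM

All three share one core and differ only in the group on the carbonyl carbon of the amide. In a functional assay on cells for positive allosteric modulation of metabotropic glutamate receptor 5 (Rattus norvegicus), read by calcium flux (a lower number here means that less compound is needed, a higher number that more compound is needed for the effect), compound 3 gives the highest of the three numbers. Its nearest neighbour is compound 2, and the step of a 1.4-fold higher number from compound 2 to compound 3 (0.13 log units; within the scatter) lies within the scatter, so these two cannot be ordered. Compound 1 stands furthest away: the step of a 33-fold higher number from compound 1 to compound 3 (1.52 log units; beyond the scatter) is large and beyond the scatter, as is the related step of a 25-fold higher number from compound 1 to compound 2 (1.39 log units; beyond the scatter).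

Compound 4, `O=C(CC1CCCC1)Nc1cc(-c2ccccc2)nn1-c1ccccc1`, has not yet been measured in this assay. It differs from compound 3 in one place: cyclopentylmethyl in place of cyclopentyl on a carbonyl carbon. For the measured compounds named here, none of the measured steps tests this kind of change; each of them swaps the whole group on the carbonyl carbon for a different ring, whereas here the cyclopentyl ring is kept and the carbonyl is moved one bond further from it. The two steps that involve compound 3 show that a 3-methoxyphenyl group gives a far lower number than either cyclopentyl or pyridin-4-yl, but they say nothing about lengthening the cyclopentyl side by one carbon. In the absence of a bearing step, compound 4 is expected to stay close to compound 3, with the step of a 1.0-fold higher number from compound 3 to compound 4 (0.01 log units; within the scatter) expected to lie within the scatter. Compound 4 is therefore estimated at 3500 nM in this assay, within a range from 1200 nM to 10000 nM.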

Compound 4, half-maximal effective concentration: 350 nM
For compound 4 the middle estimate is 10-fold (1.00 log units) above the measured one; measured number below the stated range.
By their numbers in this assay, from the lowest: compound 1; then compound 4; then compounds 2 and 3 (each within the scatter of the next).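

In this assay, the position on the carbonyl carbon proves sensitive to more than the identity of the ring: with the cyclopentyl ring kept and only the link to the carbonyl lengthened to give cyclopentylmethyl, there is a 9.7-fold lower number from compound 3 to compound 4 (0.99 log units; beyond the scatter). The same group also stands clear of pyridin-4-yl, with a 7.1-fold lower number from compound 2 to compound 4 (0.85 log units; beyond the scatter), but it does not match 3-methoxyphenyl, with a 3.4-fold higher number from compound 1 to compound 4 (0.54 log units; beyond the scatter), so among these compounds a ring of carbon only on this position can give a number well under those of the pyridin-4-yl and cyclopentyl amides, while the 3-methoxyphenyl amide keeps the lowest number of the four. For the compounds shown here, nothing at hand accounts for why lengthening the link shifts the number so far.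

The compounds shown leave open whether a longer chain between the ring and the carbonyl, as in 2-cyclopentylethyl, lowers the number further or reverses the shift, and whether a larger ring on the same link, as in cyclohexylmethyl, behaves alike. They also leave open whether the same lengthening would carry over to the aromatic series, as in a 3-methoxybenzyl group on the carbonyl carbon.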